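A few compounds are considered here, and "the series" means these few. Any claim that something is new, unique, unknown or untested is made for them only; others in the source may bear on it.

Working notes on the series.

Compound 1 `CCC(=O)c1ccc2c(c1)sc(=O)n2CCCCN1CCCCCC1` carries the shared core with an azepan-1-yl group at the end of the chain on the aromatic nitrogen. In an assay on cell membranes for displacement of a labelled ligand from Sigma non-opioid intracellular receptor 1 (Rattus norvegicus) (a higher number here means a weaker inhibitor, a lower number a stronger inhibitor), compound 1 gives 10.3 nM. Compound 2 `CCC(=O)c1ccc2c(c1)sc(=O)n2CCCCCN1CCCCCC1` differs from compound 1 by (azepan-1-yl)methyl in place of azepan-1-yl on a saturated chain carbon, four bonds along the chain from an aromatic nitrogen; in this assay compound 2 gives 12.2 nM, a step of a 1.2-fold higher number from compound 1 to compound 2 (0.07 log units; within the scatter). Compound 3 `CCCC(=O)c1ccc2c(c1)sc(=O)n2CCCCCN1CCCCCC1` differs from compound 2 by a methyl in place of hydrogen on a saturated chain carbon, two bonds along the chain from a carbonyl carbon; in this assay compound 3 gives 16.3 nM, a step of a 1.3-fold higher number from compound 2 to compound 3 (0.13 log units; within the scatter). The difference between the core of compound 1 and the core of compound 3 is not broken down here; the two values show no more than the scatter between them.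

Compound 4 `CCCC(=O)c1ccc2c(c1)sc(=O)n2CCCCCCN1CCCCCC1` is not yet measured. It differs from compound 3 by (azepan-1-yl)methyl in place of azepan-1-yl on a saturated chain carbon, five bonds along the chain from an aromatic nitrogen. This is the same kind of change as that from compound 1 to compound 2, made once in each pair, but the place is not the same: in the measured pair it sits four bonds along the chain from an aromatic nitrogen, here five bonds along the chain from an aromatic nitrogen. The measured step, a 1.2-fold higher number from compound 1 to compound 2 (0.07 log units; within the scatter), stayed within the scatter, so a step of about a 1.2-fold higher number from compound 3 to compound 4 (0.09 log units; within the scatter) is expected from compound 3 to compound 4 in this assay. This rests on one pair only and on a place one bond further out. For compound 4 in this assay the expected value is 20 nM, with the estimate spanning 9 nM to 45 nM.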

Compound 4, inhibition constant: 10.8 nM
For compound 4 the middle estimate is 1.9-fold (0.27 log units) above the measured one; the measured number falls inside the stated range.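

In this assay, the change of azepan-1-yl to (azepan-1-yl)methyl, read on the core of compound 3 at the place five bonds along the chain from an aromatic nitrogen, gives a 1.5-fold lower number from compound 3 to compound 4 (0.18 log units; within the scatter). Set beside the earlier step, the two readings of this change do not differ: the same change on two cores in this assay, a 1.2-fold higher number (0.07 log units; within the scatter) from compound 1 to compound 2 and a 1.5-fold lower number (0.18 log units; within the scatter) from compound 3 to compound 4, 1.8-fold (0.25 log units) apart, within the scatter of two such steps. Among these compounds, this shows that, across these two cores, the change was carried without a step beyond the scatter; it does not show that the change has any effect of its own, and with only two pairs, at two different places on the chain, it says nothing about any other core.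

The compounds shown leave open how the numbers in this assay would respond to a longer chain on the aromatic nitrogen, to a smaller amine such as piperidin-1-yl or morpholin-4-yl in place of azepan-1-yl, or to a carboxylic acid at the end of the chain. Since every step listed for this series stays within the scatter, they also leave open which change, if any, would give a step beyond it.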